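The source may hold more compounds than are shown below. What is called first, only, known or untested is meant among the compounds shown, and "the series" means these compounds.

In a functional assay on T47D cells (Homo sapiens) for cytotoxicity, read by CCK-8 assay and cell counting, with a stated time of 2 days (on this read-out higher numbers stand for weaker inhibition and lower numbers for stronger inhibition), compound 1 `Oc1ccc(-c2cc(-c3cccnc3)nc(-c3ccccc3Cl)c2)cc1` is recorded as "not determined" (no result reported), so there is no single number for where it stands. Two related compounds set the scale of the series. In this assay compound 2 `Oc1cccc(-c2cc(-c3ccc(Cl)cc3)nc(-c3ccco3)c2)c1` gives 10500 nM, and compound 3 `Oc1ccc(-c2cc(-c3ccsc3)nc(-c3cccc(Cl)c3)c2)cc1` gives 7390 nM; these two values lie within the usual scatter of each other. Compound 4 `Oc1ccc(-c2cc(-c3ccccc3)nc(-c3ccccc3Cl)c2)cc1` differs from compound 1 in one place: phenyl in place of pyridin-3-yl on an aromatic carbon. Going by the values given here, no measured pair shows this particular change, so its effect is not known from the data; the expectation is a step of no more than the usual scatter, in either direction. Compound 4 is therefore expected to show a half-maximal inhibitory concentration of about 8000 nM, with a likely range from 3000 nM to 25000 nM.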

Compound 4, half-maximal inhibitory concentration: 5460 nM
For compound 4 the middle estimate is 1.5-fold (0.17 log units) above the measured one, within the range that was stated.
By their numbers in this assay, from the lowest: compounds 4, 3 and 2 (each within the scatter of the next).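

No new step can be read from compound 4, since compound 1 has no number and compounds 2 and 3 differ from it in more than one place. Going by these compounds, what replacing pyridin-3-yl with phenyl does in this assay stays open, and no supporting evidence bears on these values.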